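Furan-3-yl replaces 4-fluorophenyl on a core without a measured number

This account rests on a few compounds, and the source may have more. Where it says the series, first, only, none or still open, it means among the compounds named here.

In a functional assay on K562 cells (Homo sapiens) for antiproliferative activity, with a stated time of 72 h (a lower number here means a stronger inhibitor, a higher number a weaker inhibitor), compound 1 `Nc1ncnn2c([C@@H]3O[C@H](CO)[C@@H](O)[C@H]3O)cc(C#Cc3ccccc3)c12` gives > 100000 nM, which is a limit and not a number. Compound 2 `Nc1ncnn2c([C@@H]3O[C@H](CO)[C@@H](O)[C@H]3O)cc(-c3ccc(F)cc3)c12` gives > 100000 nM, which is likewise a limit. Both compounds therefore stand at the same mark, (the limit of > 100000 nM in this assay, at which 2 of the 2 values shown sit), and compound 2 has no number of its own to start from.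

Among the compounds with values here, the only measured step, a step that the two limits leave unreadable from compound 1 to compound 2, gives no size to carry forward. Compound 3 `Nc1ncnn2c([C@@H]3O[C@H](CO)[C@@H](O)[C@H]3O)cc(-c3ccoc3)c12` makes a further change: furan-3-yl in place of 4-fluorophenyl on an aromatic carbon. In words, furan-3-yl takes the place of 4-fluorophenyl on an aromatic carbon of the five-membered aromatic ring with 1 nitrogen. Within the data shown here, no measured compound carries furan-3-yl, so the size of this step remains a wide guess.

With compound 2 at the limit, any readable change in this assay could only run towards stronger inhibition, and a second reading at the limit remains quite possible. A moderate gain is expected, with large uncertainty. The estimated change is an at least 10-fold lower number from compound 2 to compound 3 (1.00 log units; beyond the scatter). For compound 3, the expected value is 10000 nM, with an estimated range of 300 nM to 100000 nM.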

Compound 3, half-maximal inhibitory concentration: 2100 nM
Compound 3: middle estimate off by 4.8-fold (0.68 log units), on the high side; low and high end bracket the measured number.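

Compound 3 gives 2100 nM in this assay, which shows that this aromatic carbon of the shared core can carry a group that leaves a readable antiproliferative value. The outcome depends on the group placed there, with the core otherwise unchanged: replacing 4-fluorophenyl with furan-3-yl gives an at least 47-fold lower number from compound 2 to compound 3 (1.67 log units; beyond the scatter), and replacing 2-phenylethynyl with furan-3-yl gives an at least 47-fold lower number from compound 1 to compound 3 (1.67 log units; beyond the scatter). Neither step has an exact size, as both start from a limit and not a number: the limit of > 100000 nM in this assay, at which 2 of the 3 values shown sit.

The compounds shown do not separate the contributions of the changes that come together in furan-3-yl, which has fewer heavy atoms than 4-fluorophenyl, a five-membered rather than a six-membered ring, and a ring oxygen with its hydrogen-bond acceptor. Thus it remains open whether the gain in this assay follows the smaller ring or the oxygen atom, a question that a thiophen-3-yl or an unsubstituted phenyl group at this carbon would address.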